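The source may report more compounds than this note shows. Statements on the series, on what has been measured and on what is new or still open speak of the compounds shown alone.

Measured so far:
- compound 1 `O=C(O)CC/C=C\CC1COC(c2ccc(Cl)cc2Cl)OC1c1cccnc1`: 891 nM
- compound 2 `O=C(O)CC/C=C\CC1COC(c2ccc(C(F)(F)F)cc2)OC1c1cccnc1`: 1780 nM

Both values come from a functional assay for inhibition, with Homo sapiens as the target; a higher number here means weaker binding, a lower number tighter binding. Compound 2 stands at 1780 nM, within the scatter of compound 1, so the pair gives no real separation.

The next compound is compound 3 `O=C(O)CC/C=C\CC1COC(c2ccco2)OC1c1cccnc1`. The change is furan-2-yl in place of 4-(trifluoromethyl)phenyl on a saturated ring carbon. The group sits between two ring oxygen atoms, and the pyridin-3-yl and 5-carboxypent-2-en-1-yl groups stay in place.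

Going by the values given here, only one measured step bears on this change: a 2.0-fold higher number from compound 1 to compound 2 (0.30 log units; within the scatter). It concerns the same saturated ring carbon, but it exchanges one substituted phenyl group for another. Among the compounds with values here, no compound with a five-membered aromatic ring has been measured here, so the data do not establish a direction. The expectation is therefore no step beyond the scatter, with a slight upward lean taken as a judgement call and a wide margin on both sides.

The expected change is a 1.4-fold higher number from compound 2 to compound 3 (0.15 log units; within the scatter). For compound 3 the estimated value is 2500 nM, with an expected range of 700 nM to 9000 nM.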

Compound 3, dissociation constant: 1260 nM
Estimate against measurement, compound 3: 2.0-fold (0.30 log units) above; low and high end bracket the measured number.
By their numbers in this assay, from the lowest: compounds 1, 3 and 2 (each within the scatter of the next).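

At the saturated ring carbon between two ring oxygen atoms, this assay now covers a five-membered aromatic ring with 1 hetero atom as well as substituted phenyl groups. Furan-2-yl, with 5 heavy atoms, fewer than in 4-(trifluoromethyl)phenyl, gives a 1.4-fold lower number from compound 2 to compound 3 (0.15 log units; within the scatter), and in place of 2,4-dichlorophenyl it gives a 1.4-fold higher number from compound 1 to compound 3 (0.15 log units; within the scatter), so across these three compounds neither the change of aromatic ring nor the loss of heavy atoms separates the values. No supporting evidence accounts for this flat reading.

From the compounds shown here alone, all three compounds keep an aromatic ring at this carbon, so it remains open whether a saturated group such as cyclohexyl, a small group such as methyl, or a ring carrying an amine would stay within the same range. The pyridin-3-yl and 5-carboxypent-2-en-1-yl groups are also constant here, which leaves open how this assay would respond to a primary amide in place of the carboxylic acid, or to a longer chain at that ring atom.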